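Acyl variation on the glutamyl amide in KB cytotoxicity

The compounds below may be only part of what the source reports. "The series", "measured", "known", "first", "only" and "open" are said of these compounds alone.

Compound 2, `CCCCOC(=O)CNC(=O)[C@H](CSc1ccc([N+](=O)[O-])cc1[N+](=O)[O-])NC(=O)CC[C@H](NC(=O)CC(C)C)C(=O)OCCCC`, gives 59.6 uM in a toxicity assay on KB cells (Homo sapiens) for cytotoxicity, read by fluorescence, with a stated time of 3 days; on this read-out higher numbers stand for an effect only at larger amounts of compound and lower numbers for an effect already at smaller amounts; of the two plain numbers in hand it is the lowest. Compound 1, `CCCCOC(=O)CNC(=O)[C@H](CSc1ccc([N+](=O)[O-])cc1[N+](=O)[O-])NC(=O)CC[C@H](NC(=O)CC(C)(C)C)C(=O)OCCCC`, gives 250 uM. For compound 3, `CCCCOC(=O)CNC(=O)[C@H](CSc1ccc([N+](=O)[O-])cc1[N+](=O)[O-])NC(=O)CC[C@H](NC(=O)CCc1ccccc1)C(=O)OCCCC`, the reading is only a limit of the assay, > 300 uM. The measured steps are a 4.2-fold lower number from compound 1 to compound 2 (0.62 log units; beyond the scatter) and an at least 5.0-fold higher number from compound 2 to compound 3 (0.70 log units; beyond the scatter), while an at least 1.2-fold higher number from compound 1 to compound 3 (0.07 log units; that floor lies within the scatter) has a floor within the scatter.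

Compound 4, `CCCCOC(=O)CNC(=O)[C@H](CSc1ccc([N+](=O)[O-])cc1[N+](=O)[O-])NC(=O)CC[C@H](NC(=O)C(C)(C)C)C(=O)OCCCC`, is not yet measured; its difference from compound 2 is tert-butyl in place of isobutyl on a carbonyl carbon. Both steps that touch this acyl group bear on it: going from compound 1 to compound 2 gave the lower number, and going from compound 2 to compound 3 gave the higher one, so departures from isobutyl in either direction of size have so far given higher numbers than compound 2. Going by the values given here, a modest rise is therefore expected, a 2.2-fold higher number from compound 2 to compound 4 (0.34 log units; beyond the scatter), though no measured step leads to tert-butyl itself. Compound 4 is estimated at 130 uM, with a range from 45 uM to 300 uM.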

Compound 4, concentration for half-maximal effect: 83.4 uM
Beside the measured number, compound 4's estimate is 1.6-fold (0.19 log units) above it; the measured number falls inside the stated range.
By their numbers in this assay, from the lowest: compounds 2 and 4 (each within the scatter of the next); then compound 1. At a limit, above all of these: compound 3.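

Working notes: in this assay, the two four-carbon acyl groups cannot be told apart at this carbonyl carbon: a 1.4-fold higher number from compound 2 to compound 4 (0.15 log units; within the scatter). Neopentyl and tert-butyl are not interchangeable at the same place, with a 3.0-fold lower number from compound 1 to compound 4 (0.48 log units; beyond the scatter), so the higher number of compound 1 does not follow from a tert-butyl end alone. Going from phenethyl to tert-butyl gives an at least 3.5-fold lower number from compound 3 to compound 4 (0.55 log units; beyond the scatter), which is only a floor, as one end of this step is a limit of the assay: the limit of > 300 uM in this assay, at which 1 of the 4 values shown sits.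

Still open, on these data alone, is how an acyl group carrying an amine or a carboxylic acid, or a longer unbranched chain, would read at this position in this assay. Also open, as far as these compounds go, is whether the same order of isobutyl, tert-butyl and neopentyl holds on any other cell type.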